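A few compounds are considered here, and "the series" means these few. Any claim that something is new, unique, unknown or untested is made for them only; others in the source may bear on it.

Measured in a functional assay on HCT-116 cells (Homo sapiens) for antiproliferative activity, read by MTT assay, with a stated time of 72 h; a higher number here means a weaker inhibitor, a lower number a stronger inhibitor
- compound 1 (`O=C(CCc1cccc2c1B(O)OC2)Nc1cccc(-c2cccc(F)c2)c1`) gives 460 nM
- compound 2 (`O=C(CCc1cccc2c1B(O)OC2)Nc1cccc(-c2ccc(C(F)(F)F)cc2)c1`) gives 550 nM

For the measured compounds named here, compound 2 (550 nM) lies within the scatter of compound 1, the only other compound measured so far. Compound 3 (`N#Cc1ccc(-c2cccc(NC(=O)CCc3cccc4c3B(O)OC4)c2)cc1`) differs from compound 2 by a single change (cyano in place of trifluoromethyl on an aromatic carbon), cyano in place of trifluoromethyl on an aromatic carbon. Going by the values given here, the only measured step (a 1.2-fold higher number from compound 1 to compound 2 (0.08 log units; within the scatter)) put 4-(trifluoromethyl)phenyl in place of 3-fluorophenyl and stayed within the scatter, so no step beyond the scatter is expected in this assay here. The expected step is small (a 1.1-fold lower number from compound 2 to compound 3 (0.04 log units; within the scatter)). For compound 3 the estimated value is 500 nM (expected range 200 nM to 1300 nM).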

Compound 3, half-maximal inhibitory concentration: 410 nM
Beside the measured number, compound 3's estimate is 1.2-fold (0.09 log units) above it, within the range that was stated.
By their numbers in this assay, from the lowest: compounds 3, 1 and 2 (each within the scatter of the next).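

In this assay, cyano in place of trifluoromethyl on this aromatic carbon gives a 1.3-fold lower number from compound 2 to compound 3 (0.13 log units; within the scatter), and 4-cyanophenyl in place of 3-fluorophenyl gives a 1.1-fold lower number from compound 1 to compound 3 (0.05 log units; within the scatter). The position therefore accepts a nitrile, a group with a triple bond and a hydrogen-bond acceptor, with all three compounds lying within the scatter of one another. No evidence on the reason for this is available. What the compounds shown leave open is whether an amine, a carboxylic acid or a longer chain on this ring would move the number beyond the scatter.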